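From Pyridin-3-yl to Pyridin-4-yl in a Nitro Compound

The source may report more compounds than this note shows. Statements on the series, on what has been measured and on what is new or still open speak of the compounds shown alone.

In a functional assay on QGY-7703 cells (Homo sapiens) for cytotoxicity, read by MTT assay, with a stated time of 24 h (on this read-out lower numbers stand for stronger inhibition and higher numbers for weaker inhibition), compound 2 `CN1C/C(=C\c2cccnc2)C(=O)/C(=C/c2cc([N+](=O)[O-])ccc2F)C1` gives 11100 nM. Compound 3 `COc1ccc(/C=C2\CN(C)C/C(=C\c3ccncc3)C2=O)c(OC)c1OC` gives 8350 nM, a value within the scatter of that of compound 2. Compound 1 `CN1C/C(=C\c2cccnc2)C(=O)/C(=C/c2ccccc2F)C1` gives 4470 nM, so compound 2 and compound 3 sit together at the higher end of these three numbers.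

The next compound, compound 4 `CN1C/C(=C\c2ccncc2)C(=O)/C(=C/c2cc([N+](=O)[O-])ccc2F)C1`, keeps everything in compound 2 except one group, with pyridin-4-yl in place of pyridin-3-yl on a double-bonded chain carbon bound to a double-bonded ring carbon.

Among the measured compounds shown here, no measured step covers this exchange. The only one available, a 2.5-fold higher number from compound 1 to compound 2 (0.40 log units; beyond the scatter), is modest and comes from adding a nitro group, which compound 4 retains, so it does not speak to the swap itself. Compound 3 offers indirect evidence, since it carries pyridin-4-yl, although it differs from compound 4 elsewhere as well. The value of compound 3 at 8350 nM gives no sign of a large shift.

No change beyond the scatter is therefore expected, and the estimated step is a 1.1-fold lower number from compound 2 to compound 4 (0.05 log units; within the scatter). For compound 4 the expected value is 9800 nM, with an estimated range from 4500 nM to 21000 nM.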

Compound 4, half-maximal inhibitory concentration: 5700 nM
Beside the measured number, compound 4's estimate is 1.7-fold (0.24 log units) above it, within the range that was stated.
By their numbers in this assay, from the lowest: compounds 1, 4, 3 and 2 (each within the scatter of the next, the first and the last beyond it).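

In this assay, among the compounds shown here, the exchange of pyridin-3-yl for pyridin-4-yl on a double-bonded chain carbon bound to a double-bonded ring carbon gives a 1.9-fold lower number from compound 2 to compound 4 (0.29 log units; within the scatter), which is the first direct reading at this place, and the two compounds cannot be separated on this read-out. For the compounds shown here, the only earlier step, a 2.5-fold higher number from compound 1 to compound 2 (0.40 log units; beyond the scatter), came from nitro in place of hydrogen on an aromatic carbon, so it said nothing about this place, whereas the new pair shows that, with the nitro group kept, these two pyridinyl groups, made of the same atoms, stay within the usual scatter of each other. No measurement in hand explains why this exchange reads as it does.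

The compounds shown leave open whether pyridin-2-yl, or a plain phenyl ring, would read the same at this place, and whether the exchange would stay as small in a compound without the nitro group. They also leave open how far a larger change elsewhere, such as an ethyl or acetyl group in place of the methyl on the shared core, would move the number.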